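Swapping the aryl tail: cytotoxicity of compound 3 expected unchanged

The compounds below may be only part of what the source reports. "The series", "measured", "known", "first", "only" and "open" are said of these compounds alone.

Measured so far:
- compound 1, `Cc1nc2c(c(-c3cc(F)c4c(c3C)CCCO4)c1[C@H](OC(C)(C)C)C(=O)O)CN(CCCc1ccc(F)cc1)CC2`, gives > 40000 nM in an ADME assay on MT2 cells (Homo sapiens) for cytotoxicity, read by XTT assay, with a stated time of 4 days; a higher number here means that more compound is tolerated, a lower number that less compound is tolerated; this is a limit of the assay, not a number.
- compound 2, `Cc1ccc(-c2c3c(nc(C)c2C(OC(C)(C)C)C(=O)O)CCN(C)C3)cc1`, gives > 40000 nM; again only a limit.

Compound 1 therefore stands at the top of what the assay can report, and so does the other measured compound: the limit of > 40000 nM in this assay, at which 2 of the 2 values shown sit. Compound 3, `Cc1ccccc1CCCN1CCc2nc(C)c([C@H](OC(C)(C)C)C(=O)O)c(-c3cc(F)c4c(c3C)CCCO4)c2C1`, differs from compound 1 by one change: 2-methylphenyl in place of 4-fluorophenyl on a saturated chain carbon, three bonds along the chain from an amine nitrogen in a ring. With both measured compounds sitting at the limit, no step beyond the scatter is expected. Compound 3 is expected to give 50000 nM, between 25000 nM and 100000 nM, most likely again reported only as a limit. The expected step that the limit leaves unreadable from compound 1 to compound 3 is none beyond the scatter.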

Compound 3, half-maximal cytotoxic concentration: > 40000 nM
Compound 3 was reported as a limit (the forecaster's own chance of this, stated with the estimate: 85%); the middle value is on the limit's open side.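

In this assay, within the data shown here, compound 1 and compound 3 are both reported only as limits, so no step between them can be read: the limit of > 40000 nM in this assay, at which 3 of the 3 values shown sit.

From the compounds shown here alone, whether 2-methylphenyl in place of 4-fluorophenyl changes the tolerated concentration at all stays open.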